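The source may hold more compounds than are shown below. What is called first, only, known or untested is meant among the compounds shown, and "the series" means these compounds.

For the measured compounds named here, compound 1 `c1ccc(COc2cccc(-c3cn([C@@H]4CN5CCC4CC5)nn3)c2)cc1` gives 6.67 nM in an assay on HEK293 cells for displacement of a labelled ligand from Neuronal acetylcholine receptor; alpha3/beta4 (Homo sapiens), read by scintillation counting, with a stated time of 120 min (a lower number here means a stronger inhibitor, a higher number a weaker inhibitor), the lowest of the two numbers so far; compound 2 `c1ccc(COc2cccc(-c3cn(C4CN5CCC4CC5)nn3)c2)cc1` gives 7.57 nM, and the step of a 1.1-fold higher number from compound 1 to compound 2 (0.05 log units; within the scatter) lies within the scatter, the pair differing only by the fact that one of compounds 1 and 2 is drawn with a defined configuration and the other without, at the place where they differ. Compound 3 `FCCCOc1cccc(-c2cn([C@@H]3CN4CCC3CC4)nn2)c1` differs from compound 1 by 2-fluoroethyl in place of phenyl on a saturated chain carbon bound to an oxygen on an aromatic ring. Going by the values given here, no measured step touches that change; the single step in hand concerns only a drawn configuration. Compound 3 is therefore estimated at 20 nM, within 5 nM to 80 nM, an expected step of a 3.0-fold higher number from compound 1 to compound 3 (0.48 log units; beyond the scatter) whose direction rests on no measured comparison.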

Compound 3, inhibition constant: 19.5 nM
Beside the measured number, compound 3's estimate is 1.0-fold (0.01 log units) above it, and the stated range covers the measured number.
By their numbers in this assay, from the lowest: compounds 1 and 2 (each within the scatter of the next); then compound 3.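

Replacing phenyl with 2-fluoroethyl, on a saturated chain carbon bound to an oxygen on an aromatic ring, gives a 2.9-fold higher number from compound 1 to compound 3 (0.47 log units; beyond the scatter) in this assay. For the compounds shown here, this is the first step beyond the scatter, and it shows that the number at this place responds to the group carried there, though only modestly, even with the ring gone. Nothing measured here accounts for this step. The step removes the phenyl ring and brings in fluorine together, so the two changes stay unseparated. On these data alone, how a plain propyl chain or a pyridine ring would read at this place remains open.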